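Chloroacetamide thioether series: aryl amide swap

A few compounds are considered here, and "the series" means these few. Any claim that something is new, unique, unknown or untested is made for them only; others in the source may bear on it.

Measured so far:
compound 1 `O=C(CSc1nnc(NC(=O)CCCCl)s1)Nc1ccc(Cl)cn1` – > 80000 nM
compound 2 `O=C(CCl)Nc1ccc(SCC(=O)Nc2ccc(Br)cn2)cc1` – 290 nM

In a functional assay on A875 cells (Homo sapiens) for antiproliferative activity, read by MTT assay, with a stated time of 48 h (a lower number here means a stronger inhibitor, a higher number a weaker inhibitor), compound 1 gives > 80000 nM, a limit of the assay and not a number (the limit of > 80000 nM in this assay, at which 1 of the 2 values shown sits). Compound 2 gives 290 nM in this assay, the only number shown, so no step between measured compounds is available. Compound 3 `O=C(CCl)Nc1ccc(SCC(=O)Nc2cccc(Cl)c2)cc1` differs from compound 2 by 3-chlorophenyl in place of 5-bromopyridin-2-yl on an amide-type nitrogen. Nothing measured bears on this change; a small loss, at the edge of the scatter, is expected, the estimated step being a 2.4-fold higher number from compound 2 to compound 3 (0.38 log units; beyond the scatter). Compound 3 is therefore expected at 700 nM, likely between 200 nM and 3000 nM.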

Compound 3, half-maximal inhibitory concentration: 7800 nM
Compound 3: middle estimate off by 11-fold (1.05 log units), on the low side, and the stated range ends below it.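

Among these compounds, this is the first step that can be read, and it shows that the group on this amide-type nitrogen is not freely exchangeable: in this assay, 3-chlorophenyl in place of 5-bromopyridin-2-yl gives a 27-fold higher number from compound 2 to compound 3 (1.43 log units; beyond the scatter). The two groups have the same heavy-atom count, yet the step is large and beyond the scatter. Nothing shown gives a cause for this step.

The swap changes the ring nitrogen and the halogen together, and the two are not separated here. A 3-bromophenyl or an unsubstituted phenyl on the same nitrogen would help to tell them apart.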